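The compounds below may be only part of what the source reports. "The series", "measured", "known", "first", "only" and "open" are said of these compounds alone.

Working notes on a small series of chalcone-type compounds bearing a pyridone-like core, all tested in a functional assay on UACC-62 cells (Homo sapiens) for inhibition; on this read-out lower numbers stand for stronger inhibition of growth and higher numbers for weaker inhibition of growth.

Compound 3 `COc1ccc(-c2cn(-c3cccc(C(=O)/C=C/c4cc(OC)c(OC)c(OC)c4)c3)c(=O)[nH]2)cc1` gives 2060 nM in this assay. Compound 2 `COc1ccc(-c2cn(-c3cccc(C(=O)/C=C/c4ccc(O)c(OC)c4)c3)c(=O)[nH]2)cc1` differs from compound 3 in the chain-linked aryl group, (4-hydroxy-3-methoxyphenyl in place of 3,4,5-trimethoxyphenyl on a double-bonded chain carbon bound to a double-bonded chain carbon). In this assay compound 2 gives 3960 nM; the step of a 1.9-fold lower number from compound 2 to compound 3 (0.28 log units; within the scatter) stays within the scatter, so the two are not ranked against each other. Compound 1 `COc1cc(/C=C/C(=O)c2cccc(-n3cc(-c4ccc(Cl)cc4)[nH]c3=O)c2)cc(OC)c1OC` carries the change chloro in place of methoxy on an aromatic carbon relative to compound 3. In this assay compound 1 gives 8880 nM; the step of a 4.3-fold higher number from compound 3 to compound 1 (0.63 log units; beyond the scatter) is a weakening beyond the scatter.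

Compound 4 `COc1cc(/C=C/C(=O)c2cccc(-n3cc(-c4ccc(Cl)cc4)[nH]c3=O)c2)ccc1O` has not yet been measured. It stands to compound 2 as compound 1 stands to compound 3: the change chloro in place of methoxy on an aromatic carbon is the same change, with identical surroundings at the place of exchange. Going by the values given here, on the single precedent it is expected to weaken growth inhibition by a 3.8-fold higher number from compound 2 to compound 4 (0.58 log units; beyond the scatter), a step comparable to a 4.3-fold higher number from compound 3 to compound 1 (0.63 log units; beyond the scatter), though one precedent gives little confidence in its exact size. Compound 4 is therefore estimated at 15000 nM in this assay, with a plausible range from 6000 nM to 38000 nM.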

Compound 4, concentration for 50% growth inhibition: 2740 nM
Compound 4: the middle estimate sits 5.5-fold (0.74 log units) above what was measured; measured number outside the range, below it.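

In this assay, on the core carrying the 4-hydroxy-3-methoxyphenyl group, the change from 4-methoxyphenyl to 4-chlorophenyl gives a 1.4-fold lower number from compound 2 to compound 4 (0.16 log units; within the scatter) and so leaves compound 2 and compound 4 unranked against each other. Going by these compounds alone, with only one pair on each core, this does not show why the two steps part, nor how the change would behave with any other chain-linked aryl group. What the pairs do show is that the step seen with the 3,4,5-trimethoxyphenyl group cannot be carried unchanged to the 4-hydroxy-3-methoxyphenyl group, as the comparison shows: the same change on two cores in this assay, a 4.3-fold higher number (0.63 log units; beyond the scatter) from compound 3 to compound 1 and a 1.4-fold lower number (0.16 log units; within the scatter) from compound 2 to compound 4, 6.2-fold (0.79 log units) apart, beyond the scatter of two such steps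

The compounds shown leave open whether a fluoro or a dimethylamino group in the same place would follow the step on either core. They also leave open how the change behaves with a chain-linked aryl group bearing a carboxylic acid or an amine, or with an unsubstituted phenyl there, so the dependence on that group rests on two pairs alone.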